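Hexyloxy in Place of Iodo on the Sulfonamide Aryl Ring

This account rests on a few compounds, and the source may have more. Where it says the series, first, only, none or still open, it means among the compounds named here.

Compound 1 `O=C1NCCN1c1ccc(S(=O)(=O)Nc2ccc(I)cc2)cc1`: 650 nM
Compound 2 `O=C1NCCN1c1ccc(S(=O)(=O)Nc2ccc(F)c(F)c2)cc1`: 350 nM
Compound 3 `O=C1NCCN1c1ccc(S(=O)(=O)Nc2cccc(Cl)c2)cc1`: 55 nM

Three compounds share one core and differ only in the aryl group on the sulfonamide nitrogen. In a functional assay on HT-29 cells (Homo sapiens) for antiproliferative activity, read by sulforhodamine B assay, with a stated time of 48 h (a lower number here means a stronger inhibitor, a higher number a weaker inhibitor), compound 1 gives 650 nM, the highest of the three numbers. The nearest is compound 2, with a 1.9-fold lower number from compound 1 to compound 2 (0.27 log units; within the scatter); the furthest is compound 3, with a 12-fold lower number from compound 1 to compound 3 (1.07 log units; beyond the scatter). Between the two halogenated variants, a 6.4-fold lower number from compound 2 to compound 3 (0.80 log units; beyond the scatter).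

Compound 4 `CCCCCCOc1ccc(NS(=O)(=O)c2ccc(N3CCNC3=O)cc2)cc1` is not yet measured. It differs from compound 1 in one place: hexyloxy in place of iodo on an aromatic carbon. The change sits para to a large group, as the iodo did in compound 1.

Within the data shown here, none of the measured steps replaces a halogen with an alkoxy chain; they only exchange one halogen pattern for another, and the larger of them, from compound 1 to compound 3, moved the substituent to a different ring position, which compound 4 does not do. The closest guide is the step from compound 1 to compound 2, which stayed within the scatter. Compound 4 is therefore expected to change the number in this assay by a 1.2-fold lower number from compound 1 to compound 4 (0.07 log units; within the scatter), with a wide range around the estimate 550 nM (150 nM to 2500 nM).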

Compound 4, half-maximal inhibitory concentration: > 1000 nM
Compound 4 gave a limit, no number; the forecaster's own chance of this, stated with the estimate: 5%; middle value at least 1.8-fold (0.25 log units) away from the limit.
By their numbers in this assay, from the lowest: compound 3; then compounds 2 and 1 (each within the scatter of the next). At a limit, above all of these: compound 4.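

Compound 4 gives > 1000 nM in this assay, which is a limit of the assay and not a number. The earlier steps shown here only exchanged one halogen pattern for another, whereas this one puts a hexyloxy chain on the aromatic carbon that carried iodo, para to a large group, and the result is an at least 1.5-fold higher number from compound 1 to compound 4 (0.18 log units; that floor lies within the scatter) as a floor only, so the true size of the change cannot be read and may be anything from within the scatter upward. What it adds is that this alkoxy chain, at this position, does not bring the number in this assay under the limit, and compound 4 alone among the compounds shown stands there: the limit of > 1000 nM in this assay, at which 1 of the 4 values shown sits.

The compounds shown leave open whether a shorter chain such as methoxy, or an amine or a carboxylic acid, in place of iodo would give a readable number in this assay. They also leave open whether hexyloxy in place of the chloro of compound 3 would reach the same limit or keep a readable number.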